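The compounds below may be only part of what the source reports. "The series", "measured", "known", "first", "only" and "open" are said of these compounds alone.

Compound 3 `CN(C)C(=O)c1cc2cnc(Nc3ccc(C(=O)NCCCN=C=S)cc3F)nc2n1C1CCCC1` stands lowest of the three measured compounds in a functional assay on A549 cells (Homo sapiens) for inhibition, read by CCK-8 assay, with a stated time of 72 h, tested at 10 uM (a higher number here means a stronger effect of the compound at the concentration tested, a lower number a weaker effect), where compound 3 gives 60.2%. Compound 2 `CN(C)C(=O)c1cc2cnc(Nc3ccc(C(=O)NCCCN=C=S)cc3)nc2n1C1CCCC1` gives 103%, and compound 1 `CN(C)C(=O)c1cc2cnc(Nc3ccc(S(=O)(=O)NCCCCCCCN=C=S)cc3)nc2n1C1CCCC1` gives 101%. Going by the values given here, the only single-place step measured is a number 42.8 percentage points lower from compound 2 to compound 3 (beyond the scatter). Compound 4 `CN(C)C(=O)c1cc2cnc(Nc3ccc(C(=O)NCCCCCN=C=S)cc3F)nc2n1C1CCCC1` differs from compound 3 in another way: a group of 5 heavy atoms (3 carbon, 1 nitrogen, 1 sulfur; no ring) in place of a group of 3 heavy atoms (1 carbon, 1 nitrogen, 1 sulfur; no ring), on a saturated chain carbon, three bonds along the chain from an amide-type nitrogen. Among the compounds with values here, no measured step bears on lengthening this chain; compound 1 carries a longer chain but differs in further places, so its value shows only that a long chain can go with a high reading. The expected change is therefore small, a number 7.8 percentage points higher from compound 3 to compound 4 (within the scatter), with an uncertain direction. Compound 4 is estimated at 68%, between 42% and 94%.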

Compound 4, a percentage reported as inhibition, at one concentration (the size of the read-out at that concentration, not a potency): 15.6%
For compound 4 the middle estimate is 52.4 percentage points above the measured one; the whole stated range lies above it.
By their numbers in this assay, from the lowest: compound 4; then compound 3; then compounds 1 and 2 (each within the scatter of the next).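

Going by these compounds alone, this is the first measured step at the chain, and it shows that the position is sensitive in this assay: the group of 5 heavy atoms in place of the group of 3 heavy atoms gives a number 44.6 percentage points lower from compound 3 to compound 4 (beyond the scatter). Adding only two chain carbons is therefore enough to change the reading strongly in this fluoro-bearing series. Nothing available explains the drop. On these data alone, whether the same lengthening lowers the number in a compound with hydrogen in place of fluoro remains open. So does what a still longer chain, or an amine at the chain end, would give.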